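Shortening the Ester Chain at the Carbonyl of Compound 2

The compounds below may be only part of what the source reports. "The series", "measured", "known", "first", "only" and "open" are said of these compounds alone.

Measured compounds:
compound 1, `CCN(CC)C(=O)C1=C(C)NC(=O)NC1c1ccsc1`: 11%
compound 2, `CCC(CC)OC(=O)C1=C(C)NC(=O)NC1c1ccsc1`: 26%

In an assay on membranes from HEK293 cells for displacement of a labelled ligand from adenosine receptor A2b (Homo sapiens), read by scintillation counting, with a stated time of 30 min, tested at 1 uM (a higher number here means more inhibition at the concentration tested (going by the name of the read-out), a lower number less inhibition), compound 1 gives 11% and compound 2 gives 26%. Among the measured compounds shown here, compound 2 therefore stands highest of the two numbers, with compound 1 as its nearest neighbour, and the single step between them, a number 15 percentage points higher from compound 1 to compound 2 (beyond the scatter), is modest but beyond the scatter.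

Compound 3, `CCC(C)OC(=O)C1=C(C)NC(=O)NC1c1ccsc1`, has not yet been measured in this assay. Its difference from compound 2 is hydrogen in place of methyl on a saturated chain carbon, two bonds along the chain from an oxygen next to a carbonyl group; cut one bond further out, the same change reads (pentan-3-yl)oxy to sec-butoxy.

For the measured compounds named here, no measured step bears directly on this change: the only step in hand replaces diethylamino with (pentan-3-yl)oxy on the carbonyl carbon and leaves the chain itself untouched. It shows that the carbonyl substituent can move the number, but it gives no guidance on trimming one methyl from the ester chain. On that basis the step from compound 2 to compound 3 is expected to be small, a number 4 percentage points lower from compound 2 to compound 3 (within the scatter), and likely within the scatter.

Compound 3 is thus estimated at 22% in this assay, with a range from 8% to 38%.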

Compound 3, a percentage reported as inhibition, at one concentration (the size of the read-out at that concentration, not a potency): 39%
Compound 3: the middle estimate sits 17 percentage points below what was measured, outside the stated range (above it).
By their numbers in this assay, from the lowest: compound 1; then compound 2; then compound 3.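

In this assay, removing a single methyl from the saturated chain carbon, two bonds along the chain from an oxygen next to a carbonyl group, gives a number 13 percentage points higher from compound 2 to compound 3 (beyond the scatter), so the ester chain itself affects the read-out and not only the group's attachment to the carbonyl carbon. Against the amide, sec-butoxy in place of diethylamino gives a number 28 percentage points higher from compound 1 to compound 3 (beyond the scatter), and compound 3 now stands beyond the scatter from both other compounds, with the pentan-3-yl ester no longer the highest of the series. No independent measurement is available to account for this rise from the shorter ester.

The compounds shown leave open whether the number would keep climbing with a still shorter ester such as ethoxy or methoxy, or whether the branching matters, which an unbranched n-butoxy chain would test. Among the compounds shown here, they also leave open how a carboxylic acid or a small secondary amide at the same carbonyl carbon would compare, since diethylamino is the only nitrogen group represented there.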